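A few compounds are considered here, and "the series" means these few. Any claim that something is new, unique, unknown or untested is made for them only; others in the source may bear on it.

Measured so far:
- compound 1, `CC(C)NC(=O)/C=C/c1ccccc1`: 76%
- compound 2, `CCCCCCCCCCNC(=O)/C=C/c1ccccc1`: 15%

Both were tested in a functional assay on the whole organism for inhibition, with Brassica rapa subsp. chinensis as the target, with a stated time of 3 days, tested at 100 ppm; on this read-out higher numbers stand for more inhibition of growth at the one concentration tested and lower numbers for less inhibition of growth. Compound 1 stands highest of the two numbers; its nearest neighbour is compound 2, whose value lies far enough below to sit beyond the usual scatter of this assay. Within the data shown here, the two share the same core and differ only in the group attached to the carbonyl carbon, but no single-place step between them has been worked out, so only the two values themselves can be compared.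

Compound 3, `CC(C)OC(=O)/C=C/c1ccccc1`, has not been measured. It differs from compound 1 by isopropoxy in place of isopropylamino on a carbonyl carbon. Among the measured compounds shown here, no step of this kind has been measured here, so the direction is uncertain; a moderate drop in growth inhibition from compound 1 is expected, but one that could well fall within the scatter. The estimated step is a number 21 percentage points lower from compound 1 to compound 3 (beyond the scatter). Compound 3 is therefore expected to give 55%, with a range from 25% to 85%.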

Compound 3, percent growth inhibition at one concentration: 2%
Compound 3: middle estimate off by 53 percentage points, on the high side; the whole stated range lies above it.
By their numbers in this assay, from the lowest: compound 3; then compound 2; then compound 1.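

In this assay isopropoxy in place of isopropylamino on a carbonyl carbon gives a number 74 percentage points lower from compound 1 to compound 3 (beyond the scatter) and so shows that this position does not accept every group of the same size. The two groups have the same number of heavy atoms and neither has a ring or a net charge, but the swap exchanges nitrogen for oxygen and removes the one hydrogen-bond donor, and most of the growth inhibition goes with it. Nothing available here accounts for a step this large.

The compounds shown leave open whether the nitrogen or the amide hydrogen on it is what counts, a question that a dimethylamino group on the same carbonyl carbon would help to settle. They also leave open how a free carboxylic acid would behave at this position.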